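The source may hold more compounds than are shown below. What is called first, only, known or untested is meant among the compounds shown, and "the series" means these compounds.

Compound 1 `CC1(c2ccccc2)CC(=O)C(C2CC(c3ccc(OCc4ccc(C(F)(F)F)cc4)cc3)Cc3ccccc32)=C(O)O1` and compound 2 `CCC1(c2ccccc2)CC(=O)C(C2CC(c3ccc(-c4ccc(Br)cc4)cc3)Cc3ccccc32)=C(O)O1` share the same core and differ in the pendant aryl group as well as in a methyl against an ethyl on that core. In a functional assay on SK-MEL-2 cells (Homo sapiens) for inhibition, with a stated time of 72 h (on this read-out lower numbers stand for stronger inhibition and higher numbers for weaker inhibition), compound 1 gives only a limit of the assay, > 10000 nM. Compound 2 likewise gives only a limit in this assay, > 10000 nM. Both readings thus rest at the limit of > 10000 nM in this assay, at which 2 of the 2 values shown sit, so neither compound can be ordered against the other on a number. Compound 3 `CCC1(c2ccccc2)CC(=O)C(C2CC(c3ccc(OCc4ccc(C(F)(F)F)cc4)cc3)Cc3ccccc32)=C(O)O1` is the compound still to be measured; it carries (4-(trifluoromethyl)benzyl)oxy in place of 4-bromophenyl on an aromatic carbon, which is the same pendant group that compound 1 already bears. Within the data shown here, no measured step exists between compound 2 and compound 3, and because compound 1 with this very group already stands at the limit of > 10000 nM in this assay, at which 2 of the 2 values shown sit, no shift beyond the usual scatter is expected from this change in this assay. Compound 3 is therefore expected to give about 15000 nM in this assay, within a range from 5000 nM to 50000 nM, most probably reported once more as a limit rather than a number. The expected step that the limit leaves unreadable from compound 2 to compound 3 is accordingly estimated as essentially none.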

Compound 3, half-maximal inhibitory concentration: > 10000 nM
Compound 3: a limit, no number; the forecaster's own chance of this, stated with the estimate: 80%; the middle value lies beyond the limit too.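

In this assay compound 3 gives only a limit (> 10000 nM). Among these compounds, no step from compound 1 or compound 2 to compound 3 can be read, and the three compounds cannot be ordered: (the limit of > 10000 nM in this assay, at which 3 of the 3 values shown sit). The compounds shown leave open whether the pendant group or the methyl against ethyl on the core changes inhibition in this assay at all.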